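Ester-to-acid change on the acrylate of compound 1

The source may hold more compounds than are shown below. What is called first, only, known or untested is meant among the compounds shown, and "the series" means these compounds.

Within the three measured members, compound 1 `CCOC(=O)/C=C/c1ccncc1-c1ccc2[nH]ccc2c1` gives the lowest number in an assay on a protein complex for inhibition of CDK8/Cyclin C (Homo sapiens), with a stated time of 1 h (a higher number here means a weaker inhibitor, a lower number a stronger inhibitor), at 107 nM. Compound 3 `CNC(=O)/C=C/c1ccncc1-c1ccc2cnn(C)c2c1` gives 122 nM and compound 2 `CCOC(=O)/C=C/c1ccncc1-c1ccc2c(ccn2C)c1` gives 144 nM; both sit within the scatter of compound 1, so no order among the three can be read. For the measured compounds named here, the one measured step, a 1.3-fold higher number from compound 1 to compound 2 (0.13 log units; within the scatter), concerns methyl in place of hydrogen on an aromatic nitrogen and does not touch the acrylate terminus.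

Compound 4 `O=C(O)/C=C/c1ccncc1-c1ccc2[nH]ccc2c1` differs from compound 1 by hydrogen in place of ethyl on an oxygen next to a carbonyl group. Going by the values given here, no measured pair addresses the ethyl ester against the free carboxylic acid; compound 3 carries a methylamide at that position, but on a different ring system, so its value shows nothing separable about the terminus. The expectation therefore rests only on compound 1 and carries wide uncertainty; a modest weakening is estimated, a 2.4-fold higher number from compound 1 to compound 4 (0.39 log units; beyond the scatter), with the step possibly not beyond the scatter. Compound 4 is estimated at 260 nM, with a range of 55 nM to 1300 nM.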

Compound 4, half-maximal inhibitory concentration: 17 nM
Estimate against measurement, compound 4: 15-fold (1.18 log units) above; measured number below the stated range.
By their numbers in this assay, from the lowest: compound 4; then compounds 1, 3 and 2 (each within the scatter of the next).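

Going from 2-(ethoxycarbonyl)ethenyl to 2-carboxyethenyl gives a 6.3-fold lower number from compound 1 to compound 4 (0.80 log units; beyond the scatter) in this assay. Of the two steps shown, only this one lies beyond the scatter; the other, methyl in place of hydrogen on an aromatic nitrogen, gives a 1.3-fold higher number from compound 1 to compound 2 (0.13 log units; within the scatter) and stays within it, so this position is the first shown to register in the numbers, and the ethyl group is not required for binding at this level. Nothing measured here explains the step.

On these data alone, it remains open how a methyl ester or a primary amide would read on the core of compound 1, and so whether the gain is specific to the carboxy group. As far as these compounds go, it is also open whether the same change would give a similar step on the core of compound 2 or compound 3.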